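Longer Chains, Lower Numbers: What Comes After Compound 3

The source may report more compounds than this note shows. Statements on the series, on what has been measured and on what is new or still open speak of the compounds shown alone.

Of the compounds shown here, three sharing one core have been tested in a functional assay on HCT-116 cells (Homo sapiens) for antiproliferative activity, read by MTT assay, with a stated time of 48 h; on this read-out lower numbers stand for stronger inhibition and higher numbers for weaker inhibition. Compound 1 `CCCCC(CCO)n1cnc2c(Cl)ncnc21` reaches only a limit of the assay, > 50000 nM. Among the measured compounds shown here, compound 2 `CCCCCCCC(CCO)n1cnc2c(Cl)ncnc21` gives 4160 nM, and compound 3 `CCCCCCCCCC(CCO)n1cnc2c(Cl)ncnc21` gives 890 nM, the lowest number so far.

Compound 4 `CCCCCCCCCCCCC(CCO)n1cnc2c(Cl)ncnc21` extends the chain further, with propyl in place of hydrogen on a saturated chain carbon, ten or more bonds along the chain from an aromatic nitrogen.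

Three earlier extensions bear on this change. Two were large, an at least 12-fold lower number from compound 1 to compound 2 (1.07 log units; beyond the scatter) and an at least 56-fold lower number from compound 1 to compound 3 (1.74 log units; beyond the scatter), but both are measured from a limit. For the measured compounds named here, the only step between two true numbers, a 4.7-fold lower number from compound 2 to compound 3 (0.67 log units; beyond the scatter), was modest. Going by the values given here, each longer chain has so far given a lower number, and no tested compound goes against this. On the strength of that last step, a further modest fall is expected in this assay, although the trend may flatten. The expected change is a 2.5-fold lower number from compound 3 to compound 4 (0.41 log units; beyond the scatter). For compound 4 the estimated value is 350 nM, with an expected range from 100 nM to 1500 nM.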

Compound 4, half-maximal inhibitory concentration: > 50000 nM
Compound 4 was reported as a limit (the forecaster's own chance of this, stated with the estimate: 5%); middle value at least 140-fold (2.15 log units) from the limit.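

In this assay, adding propyl at this place ends the fall seen so far, giving an at least 56-fold higher number from compound 3 to compound 4 (1.74 log units; beyond the scatter), and the longer chain also loses to the shorter one in an at least 12-fold higher number from compound 2 to compound 4 (1.07 log units; beyond the scatter). The run of lower numbers with longer chains therefore holds only from compound 1 up to compound 3, and compound 4 goes against it, while the step from compound 1 to compound 4 cannot be read, both of its ends being limits. The same addition of propyl thus moves the number in opposite directions on two different chains: the same change on two cores in this assay, an at least 12-fold lower number (1.07 log units; beyond the scatter) from compound 1 to compound 2 and an at least 56-fold higher number (1.74 log units; beyond the scatter) from compound 3 to compound 4, at least 670-fold (2.82 log units) apart, beyond the scatter of two such steps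

Where the number turns upward, on a chain longer than that of compound 3 and shorter than that of compound 4, remains open. From the compounds shown here alone, it is also open whether an amine or a carboxylic acid in place of the added propyl would keep the number low.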